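The source may report more compounds than this note shows. Statements on the series, on what has been measured and on what is new or still open speak of the compounds shown alone.

Series notes. Compound 1 `CC1CC/C(=N\Nc2ccccc2C(F)(F)F)c2ncc(C(=O)O)c(=O)n21` carries a trifluoromethyl on the aromatic ring, and compound 2 `CC1CC/C(=N\Nc2ccc(C(F)(F)F)cc2)c2ncc(C(=O)O)c(=O)n21` is built from the same atoms joined differently; the difference between the two cores is not broken down here. Compound 3 `CC1CC/C(=N\Nc2ccccc2[N+](=O)[O-])c2ncc(C(=O)O)c(=O)n21` differs from compound 1 by nitro in place of trifluoromethyl on an aromatic carbon. In a functional assay on the whole organism for inhibition, with Rattus norvegicus as the target (a lower number here means that less compound is needed, a higher number that more compound is needed for the effect), compound 1 gives only a limit, > 1000 umol/kg. Compound 2 also gives only a limit in this assay, > 1000 umol/kg. For compound 3 the result in this assay is again a limit, > 1000 umol/kg. The step that the two limits leave unreadable from compound 1 to compound 3 is thus unreadable because of the limit of > 1000 umol/kg in this assay, at which 3 of the 3 values shown sit. Compound 4 `CC1CC/C(=N\Nc2ccc([N+](=O)[O-])cc2)c2ncc(C(=O)O)c(=O)n21` is not yet measured; it differs from compound 2 by nitro in place of trifluoromethyl on an aromatic carbon, the same kind of change as before, here para to a large group rather than ortho to a large group. The step that the limit leaves unreadable from compound 2 to compound 4 is expected to stay unreadable because of the limit of > 1000 umol/kg in this assay, at which 3 of the 3 values shown sit. Compound 4 is estimated at 3000 umol/kg, between 700 umol/kg and 20000 umol/kg.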

Compound 4, dose for 50% inhibition: > 320 umol/kg
Compound 4 was reported as a limit (the forecaster's own chance of this, stated with the estimate: 85%); the middle value does not contradict the limit.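

Compound 2 and compound 4 both give only limits in this assay and the step between them cannot be read. The compounds shown leave open whether nitro in place of trifluoromethyl on an aromatic carbon changes the dose needed in this assay at all.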